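Adding a Fluorine: Expected Effect on Cell Toxicity

A few compounds are considered here, and "the series" means these few. Any claim that something is new, unique, unknown or untested is made for them only; others in the source may bear on it.

Of the compounds shown here, three have been measured in an ADME assay on NIH3T3 cells (Mus musculus) for cytotoxicity, read by CCK-8 assay, with a stated time of 24 h; a lower number here means a stronger inhibitor, a higher number a weaker inhibitor. Compound 1 `C/C(=C\c1cc(-c2ccc(C)nc2)co1)C(N)=O` gives > 50000 nM, which is a limit of the assay rather than a number. Compound 2 `C/C(=C\c1ccc(-c2ccc(F)cc2)o1)C(N)=O` gives 960 nM. Compound 3 `C/C(=C\c1cc(-c2ccccc2)cs1)C(N)=O` gives > 50000 nM, again a limit rather than a number. Within the data shown here, compound 3 therefore sits at the limit of > 50000 nM in this assay, at which 2 of the 3 values shown sit, so its true value is not pinned down; compound 1 stands at the same limit, while compound 2 is the one compound with a number.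

Compound 4 `C/C(=C\c1cc(-c2ccc(F)cc2)cs1)C(N)=O` is not yet measured. It differs from compound 3 by fluoro in place of hydrogen on an aromatic carbon, so the change is small and adds no ring and no charge. Among the measured compounds shown here, no measured pair shows this same change on this core, so the expectation rests on compound 3 alone. Since compound 3 gives > 50000 nM, a limit, and the change is a single fluoro, compound 4 is expected to stay close to that limit, with the step of an at least 1.2-fold lower number from compound 3 to compound 4 (0.09 log units; that floor lies within the scatter) estimated as none beyond the scatter. The estimate for compound 4 is 40000 nM, within 8000 nM to 50000 nM.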

Compound 4, half-maximal inhibitory concentration: > 50000 nM
Compound 4: a limit, no number (the forecaster's own chance of this, stated with the estimate: 60%); middle value at least 1.2-fold (0.09 log units) away from the limit.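

Compound 3 and compound 4 both rest at the same limit in this assay, so no step between them can be read: the limit of > 50000 nM in this assay, at which 3 of the 4 values shown sit.

On these data alone, whether fluoro in place of hydrogen changes the result at all stays open, as do the true values of compound 3 and compound 4 beyond that limit.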